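The source may hold more compounds than are shown below. What is called first, only, known or untested is meant among the compounds shown, and "the series" means these compounds.

Working notes on the series. In a functional assay on HT-29 cells (Homo sapiens) for cytotoxicity, read by sulforhodamine B assay (a lower number here means a stronger inhibitor of growth, a higher number a weaker inhibitor of growth), compound 2 `COc1ccc(/C=N\NC(=S)NC(C)(C)CCC[C@](C)(O)[C@@H]2CC=C(C)CC2)cc1` gives 35200 nM and compound 1 `CC1=CC[C@@H]([C@@](C)(O)CCCC(C)(C)NC(=S)N/N=C\c2ccccc2)CC1` gives 36500 nM, so these two values lie within the scatter of each other and no order can be drawn between them. Compound 3 `CC1=CC[C@@H]([C@@](C)(O)CCCC(C)(C)NC(=S)N/N=C(/C)c2ccccc2)CC1` is still unmeasured. Its difference from compound 2 is a group of 9 heavy atoms (8 carbon, 1 nitrogen; one six-membered aromatic ring of carbon only) in place of a group of 10 heavy atoms (8 carbon, 1 nitrogen, 1 oxygen; one six-membered aromatic ring of carbon only), on an amide-type nitrogen. Going by the values given here, only one measured step bears on this change: a 1.0-fold lower number from compound 1 to compound 2 (0.02 log units; within the scatter). It lies within the scatter and covers only the methoxy in place of hydrogen on an aromatic carbon. Among the compounds with values here, the rest of the change has no measured step behind it, so the basis for the expectation is thin. With only these compounds to go on, no step beyond the scatter is expected in this assay, and no direction is favoured. The estimated step is a 1.1-fold lower number from compound 2 to compound 3 (0.03 log units; within the scatter). For compound 3 the estimated value is 33000 nM, with an expected range from 15000 nM to 65000 nM. Within the data shown here, the range is kept wide because the only measured step, a 1.0-fold lower number from compound 1 to compound 2 (0.02 log units; within the scatter), says nothing about the remaining part of the change.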

Compound 3, concentration for total growth inhibition: > 100000 nM
Compound 3: only a limit was reported; the forecaster's own chance of this, stated with the estimate: 10%; middle value at least 3.0-fold (0.48 log units) from the limit.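

In this assay compound 3 is reported only as > 100000 nM, which is a limit of the assay and not a number. Compound 1 and compound 2 showed only that methoxy in place of hydrogen on an aromatic carbon left no readable difference, whereas the group of 9 heavy atoms on the amide-type nitrogen gives an at least 2.7-fold higher number from compound 1 to compound 3 (0.43 log units; beyond the scatter) and an at least 2.8-fold higher number from compound 2 to compound 3 (0.45 log units; beyond the scatter), so growth inhibition at this position does respond to a change in this group. Both steps are minimum sizes set by the limit, and their full size cannot be read: the limit of > 100000 nM in this assay, at which 1 of the 3 values shown sits.

The compounds shown leave open whether an ethyl group or a longer chain in this group would read as compound 3 does in this assay, or whether a smaller change in this group would already give a step beyond the scatter. Also open, on these data alone, is whether methoxy in place of hydrogen on an aromatic carbon of compound 3 would give a readable value.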